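One Aryl Swap on an Aromatic Nitrogen, One Expected Value

A few compounds are considered here, and "the series" means these few. Any claim that something is new, unique, unknown or untested is made for them only; others in the source may bear on it.

Of the compounds shown here, three of the shared core have been tested in a functional assay on A549 cells (Homo sapiens) for antiproliferative activity, read by MTT assay, with a stated time of 48 h; a higher number here means a weaker inhibitor, a lower number a stronger inhibitor. Compound 1, `N#CC1=C(N)Oc2c(c3nc4ccccc4nc3c3ccccc23)C12C(=O)N(Cc1cnnn1-c1ccccc1Br)c1ccccc12`, returns only a limit of the assay, > 50000 nM. Compound 2, `N#CC1=C(N)Oc2c(c3nc4ccccc4nc3c3ccccc23)C12C(=O)N(Cc1cnnn1-c1cc(Cl)ccc1Cl)c1ccccc12`, likewise gives only a limit, > 50000 nM. The step that the two limits leave unreadable from compound 1 to compound 2 cannot be sized because both of its ends sit at the limit of > 50000 nM in this assay, at which 2 of the 3 values shown sit.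

Going by the values given here, compound 3, `N#CC1=C(N)Oc2c(N)cc3nc4ccccc4nc3c2C12C(=O)N(Cc1cnnn1-c1cccc(Br)c1)c1ccccc12`, is the one member with a number: in this assay compound 3 gives 18900 nM, and it therefore stands alone as the single point from which any comparison can start.

Compound 4, `COc1ccc(OC)c(-n2nncc2CN2C(=O)C3(C(C#N)=C(N)Oc4c(N)cc5nc6ccccc6nc5c43)c3ccccc32)c1`, has not been measured. It differs from compound 3 in a single place: 2,5-dimethoxyphenyl in place of 3-bromophenyl on an aromatic nitrogen. Among the compounds with values here, the only measured step that changes the group on the same aromatic nitrogen is a step that the two limits leave unreadable from compound 1 to compound 2, and its size is not readable. Within the data shown here, no measured step, then, offers either a direction or a size for this change, and the expectation can only rest on compound 3 itself. The estimated step is a 1.1-fold higher number from compound 3 to compound 4 (0.02 log units; within the scatter), which is expected to stay within the usual scatter. Compound 4 is therefore estimated at 20000 nM in this assay, with a range from 7000 nM to 60000 nM.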

Compound 4, half-maximal inhibitory concentration: 28100 nM
Compound 4: middle estimate off by 1.4-fold (0.15 log units), on the low side; the range from low to high includes it.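

In this assay, going by these compounds alone, the change on the aromatic nitrogen now has a readable size for the first time: a 1.5-fold higher number from compound 3 to compound 4 (0.17 log units; within the scatter). The 3-bromophenyl and 2,5-dimethoxyphenyl groups differ in their heavy atoms and in their hydrogen-bond acceptors, yet compound 3 and compound 4 cannot be told apart in this assay, so this position tolerates at least this one exchange without a change that exceeds the usual scatter. The earlier step between the two aryl groups of compound 1 and compound 2 still cannot be read, because both of its ends are limits of the assay and not numbers: the limit of > 50000 nM in this assay, at which 2 of the 4 values shown sit.

The compounds shown carry only halogen and methoxy groups on this aryl ring, so it remains open whether an amine or a carboxylic acid there, or a longer alkyl chain in place of the ring, would move the value beyond the scatter. As far as these compounds go, it also remains open whether the 2,5-dimethoxyphenyl group would behave the same way on the core of compound 1, where only limits are available so far.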